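This account rests on a few compounds, and the source may have more. Where it says the series, first, only, none or still open, it means among the compounds named here.

Measured compounds in a functional assay on MCF7 cells (Homo sapiens) for antiproliferative activity, read by sulforhodamine B assay, with a stated time of 48 h; a lower number here means a stronger inhibitor of growth, a higher number a weaker inhibitor of growth:
compound 1 `O=C(NCc1cn(Cc2ccc(F)cc2)nn1)c1cn(-c2ccccc2)nc1-c1ccccc1`, compound 1 gives 7000 nM
compound 2 `O=C(NCc1cn(Cc2ccc(F)cc2)nn1)c1cn(-c2ccccc2)nc1-c1ccc(F)cc1`, compound 2 gives 55300 nM
compound 3 `O=C(NCc1cn(Cc2ccc(F)cc2)nn1)c1cn(-c2ccccc2)nc1-c1ccc(Cl)cc1`, compound 3 gives 570 nM

Compound 3 holds the lowest number of the three. Its nearest neighbour is compound 1, a 12-fold lower number from compound 1 to compound 3 (1.09 log units; beyond the scatter); the furthest is compound 2, a 97-fold lower number from compound 2 to compound 3 (1.99 log units; beyond the scatter). Compound 2 itself sits well above compound 1, a 7.9-fold higher number from compound 1 to compound 2 (0.90 log units; beyond the scatter). All three steps concern the aryl ring attached to the shared core and nothing else.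

Compound 4 `COc1ccc(Cn2cc(CNC(=O)c3cn(-c4ccccc4)nc3-c3ccc(Cl)cc3)nn2)cc1` differs from compound 3 on the other side of the molecule: methoxy in place of fluoro on an aromatic carbon. For the measured compounds named here, no measured pair varies this ring, so no step bears on the change directly; the steps on the core-bound aryl ring, although large, say nothing about a 4-fluorobenzyl to 4-methoxybenzyl exchange. Going by the values given here, the only guidance is that compound 3 is the best starting point in this assay, and that a change at this remote position is not expected to move the number beyond the usual scatter in either direction. The step from compound 3 to compound 4 is therefore estimated as a 1.4-fold higher number from compound 3 to compound 4 (0.15 log units; within the scatter), with a wide band to cover the absence of direct evidence. For compound 4 the expected value is 800 nM, estimated within 250 nM to 2500 nM.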

Compound 4, concentration for 50% growth inhibition: 8000 nM
Compound 4: the middle estimate sits 10-fold (1.00 log units) below what was measured; the whole stated range lies below it.
By their numbers in this assay, from the lowest: compound 3; then compounds 1 and 4 (each within the scatter of the next); then compound 2.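

In this assay, the benzyl side of the molecule proves to be a sensitive position, not a silent one: a 14-fold higher number from compound 3 to compound 4 (1.15 log units; beyond the scatter). In size this step stands with a 12-fold lower number from compound 1 to compound 3 (1.09 log units; beyond the scatter) on the core-bound aryl ring, although it runs in the opposite direction, so changes at both ends of the molecule can move the number well beyond the scatter. The low number of compound 3 therefore depends, in this chlorophenyl setting, on the fluoro of the 4-fluorobenzyl group as well as on the chloro at the other end, and no measurement in hand accounts for the size of this step.

As far as these compounds go, with a single pair at this position, it remains open whether fluoro favours growth inhibition or methoxy disfavours it, a question that hydrogen, chloro, hydroxyl or an amine on the same aromatic carbon could help to settle. From the compounds shown here alone, it also remains open whether the step from 4-fluorobenzyl to 4-methoxybenzyl would have the same size and direction with phenyl or 4-fluorophenyl in place of the 4-chlorophenyl group on the shared core.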